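A few compounds are considered here, and "the series" means these few. Any claim that something is new, unique, unknown or untested is made for them only; others in the source may bear on it.

Compound 1 `CC1CCCN1CCCOc1ccc2c(c1)C(=O)N(C)CC2`: 26 nM in an assay on cerebellum for displacement of a labelled ligand from histamine H1 receptor (Cavia porcellus), read by scintillation counting, with a stated time of 60 min; a higher number here means a weaker inhibitor, a lower number a stronger inhibitor; compound 2 `CCN1CCN(CCCOc2ccc3c(c2)C(=O)N(C)CC3)CC1`: 1100 nM.

Compound 1 has the lower of these two numbers; its nearest neighbour, compound 2, differs by a 42-fold higher number from compound 1 to compound 2 (1.63 log units; beyond the scatter). Compound 3 `CN1CCc2ccc(OCCCN3CCC(O)C3)cc2C1=O` has not yet been measured in this assay. It differs from compound 1 by 3-hydroxypyrrolidin-1-yl in place of 2-methylpyrrolidin-1-yl on a saturated chain carbon, three bonds along the chain from an oxygen on an aromatic ring. For the measured compounds named here, only the step from compound 1 to compound 2 bears on this change, and it was large, yet there the ring itself was replaced, while here the five-membered ring is kept and only its substituent changes. A smaller weakening than that step is therefore expected, about a 3.8-fold higher number from compound 1 to compound 3 (0.59 log units; beyond the scatter). Compound 3 is estimated at 100 nM, within 30 nM to 400 nM.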

Compound 3, inhibition constant: 112 nM
The estimate for compound 3 lay 1.1-fold (0.05 log units) below the measured number, within the range that was stated.
By their numbers in this assay, from the lowest: compound 1; then compound 3; then compound 2.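

In this assay, the ring can stay five-membered and still lose ground: 3-hydroxypyrrolidin-1-yl in place of 2-methylpyrrolidin-1-yl gives a 4.3-fold higher number from compound 1 to compound 3 (0.63 log units; beyond the scatter). Against 4-ethylpiperazin-1-yl at the same place, the hydroxylated ring recovers much of the gap, with a 9.8-fold lower number from compound 2 to compound 3 (0.99 log units; beyond the scatter). No evidence at hand accounts for either step.

Still open, going by these compounds, is whether the weakening goes with losing the methyl or gaining the hydroxyl, which plain pyrrolidin-1-yl on the same chain would separate. Piperidin-1-yl there would test whether a six-membered ring alone carries the larger loss.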